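From Naphthyl to Pyridyl on a Shared Fused Core

This account rests on a few compounds, and the source may have more. Where it says the series, first, only, none or still open, it means among the compounds named here.

Of the compounds shown here, three sharing one core have been measured in a functional assay on AGS cells (Homo sapiens) for cytotoxicity, read by MTT assay, with a stated time of 48 h; on this read-out lower numbers stand for stronger inhibition and higher numbers for weaker inhibition. Compound 1 `Cc1nc2c3ccccc3ccc2c2nc3c(ccc4ccccc43)c(-c3cccc([N+](=O)[O-])c3)c12` gives 25500 nM. Compound 2 `Cc1nc2c3ccccc3ccc2c2nc3c(ccc4ccccc43)c(-c3ccccc3)c12` reaches only the assay limit of > 80000 nM (the limit of > 80000 nM in this assay, at which 1 of the 3 values shown sits). Compound 3 `Cc1nc2c3ccccc3ccc2c2nc3c(ccc4ccccc43)c(-c3cccc4ccccc34)c12` gives 12100 nM, the lowest of the two numbers recorded, with compound 1 the nearest through a 2.1-fold lower number from compound 1 to compound 3 (0.32 log units; beyond the scatter).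

Compound 4 `Cc1nc2c3ccccc3ccc2c2nc3c(ccc4ccccc43)c(-c3cccnc3)c12` has not been measured. It differs from compound 3 by pyridin-3-yl in place of naphthalen-1-yl on an aromatic carbon. For the measured compounds named here, the steps that bear on this change are the two leading into compound 3: an at least 6.6-fold lower number from compound 2 to compound 3 (0.82 log units; beyond the scatter) and a 2.1-fold lower number from compound 1 to compound 3 (0.32 log units; beyond the scatter). Both show that naphthalen-1-yl lowered the number relative to a single six-membered ring, and an at least 3.1-fold higher number from compound 1 to compound 2 (0.49 log units; beyond the scatter) shows that the unsubstituted phenyl ended at the limit. Replacing naphthalen-1-yl with pyridin-3-yl is therefore expected to raise the number beyond the scatter, the expected step being a 4.1-fold higher number from compound 3 to compound 4 (0.62 log units; beyond the scatter). Compound 4 is expected to give 50000 nM, with a range from 20000 nM to 100000 nM.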

Compound 4, half-maximal inhibitory concentration: 3960 nM
For compound 4 the middle estimate is 13-fold (1.10 log units) above the measured one; measured number outside the range, below it.
By their numbers in this assay, from the lowest: compound 4; then compound 3; then compound 1. At a limit, above all of these: compound 2.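

In this assay, the position opposite the ring nitrogen does not need the two-ring naphthalen-1-yl, since the single-ring pyridin-3-yl gives a 3.1-fold lower number from compound 3 to compound 4 (0.49 log units; beyond the scatter). The ring nitrogen is the one difference between pyridin-3-yl and phenyl, and that exchange gives an at least 20-fold lower number from compound 2 to compound 4 (1.30 log units; beyond the scatter), while the change from 3-nitrophenyl gives a 6.4-fold lower number from compound 1 to compound 4 (0.81 log units; beyond the scatter), so a single six-membered ring can outdo both the substituted phenyl and the naphthalen-1-yl here. Compound 2 stands at a limit, so its step is a bound and not an exact size: the limit of > 80000 nM in this assay, at which 1 of the 4 values shown sits.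

The compounds shown leave open how pyridin-2-yl or pyridin-4-yl would compare at this position, and whether an amine or a carboxylic acid on the ring would go further. What lies behind these steps also remains open, as the numbers record only the size of each change.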